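A few compounds are considered here, and "the series" means these few. Any claim that something is new, unique, unknown or untested is made for them only; others in the source may bear on it.

Measured compounds:
compound 1, `O=S(=O)(NCCNC(=S)Nc1ccc(Cl)cc1)c1ccc(-c2ccccc2OCc2ccccc2)s1` — 12100 nM in an ADME assay on HEK-293T cells (Homo sapiens) for cytotoxicity, read by CCK-8 assay, with a stated time of 48 h; a lower number here means a stronger inhibitor, a higher number a weaker inhibitor
compound 2, `O=[N+]([O-])c1ccc(NC(=S)NCCNS(=O)(=O)c2ccc(-c3ccccc3OCc3ccccc3)s2)cc1` — 8900 nM
compound 3, `COc1ccc(NC(=O)NCCNS(=O)(=O)c2ccc(-c3ccccc3Oc3ccc([N+](=O)[O-])c([N+](=O)[O-])c3)s2)cc1` — 18500 nM

Compound 3 gives the highest number of the three; its gap to compound 1 is within the scatter, while its gap to compound 2 is beyond it. Compound 4, `COc1ccc(NC(=O)NCCNS(=O)(=O)c2ccc(-c3ccccc3OCc3ccccc3)s2)cc1`, differs from compound 3 in one place: benzyl in place of 3,4-dinitrophenyl on an oxygen on an aromatic ring. Going by the values given here, no measured step swaps these two groups, and the only measured step, a 1.4-fold lower number from compound 1 to compound 2 (0.13 log units; within the scatter), is a different change at another place and stayed within the scatter. Since all three numbers sit close together, compound 4 is expected to land near them, with the step of a 1.4-fold lower number from compound 3 to compound 4 (0.15 log units; within the scatter) expected to stay within the scatter. Compound 4 is estimated at 13000 nM, with a range from 5500 nM to 31000 nM.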

Compound 4, half-maximal inhibitory concentration: > 50000 nM
Compound 4: no number, only a limit; the forecaster's own chance of this, stated with the estimate: 10%; at least 3.8-fold (0.58 log units) between middle value and limit.
By their numbers in this assay, from the lowest: compounds 2, 1 and 3 (each within the scatter of the next, the first and the last beyond it). At a limit, above all of these: compound 4.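

In this assay compound 4 gives no number, only a limit: the limit of > 50000 nM in this assay, at which 1 of the 4 values shown sits. Going by these compounds alone, with benzyl in place of 3,4-dinitrophenyl on the oxygen on an aromatic ring, the result is an at least 2.7-fold higher number from compound 3 to compound 4 (0.43 log units; beyond the scatter) and so this change goes beyond the scatter, which the one earlier step did not. Compound 1, compound 2 and compound 4 all carry benzyl there, yet changing the group on the amine nitrogen gives an at least 5.6-fold higher number from compound 2 to compound 4 (0.74 log units; beyond the scatter) and an at least 4.1-fold higher number from compound 1 to compound 4 (0.61 log units; beyond the scatter) as well.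

From the compounds shown here alone, the true size of these steps stays open, since each rests on a limit. Also open, going by these compounds, is what a methyl or a pyridyl group on that oxygen would give.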